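The source may hold more compounds than are shown below. What is called first, only, known or untested is meant among the compounds shown, and "the series" means these compounds.

Measured compounds:
compound 2, `O=C(NO)c1ccc(OC2CCN(c3ccccc3)C2=O)cc1` — 5740 nM
compound 3, `O=C(NO)c1ccc(NC2CCN(Cc3ccccc3)C2=O)cc1` — 510 nM
compound 1, `O=C(NO)c1ccc(NC2CCN(c3ccc(Cl)cc3)C2=O)cc1F` — "not determined" (no result reported)

For the measured compounds named here, in an assay on isolated protein for inhibition of protein deacetylase HDAC6 (Homo sapiens) (on this read-out lower numbers stand for stronger inhibition and higher numbers for weaker inhibition), compound 3 gives 510 nM and stands lowest of the two numbers known; the nearest, compound 2, gives 5740 nM, a gap beyond the usual scatter of this assay. For compound 1 no result was reported.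

Compound 4, `O=C(NO)c1ccc(NC2CCN(c3ccc(Cl)c(Cl)c3)C2=O)cc1`, differs from compound 3 in one place: 3,4-dichlorophenyl in place of benzyl on an amide-type nitrogen in a ring. Going by the values given here, no measured pair shows this kind of change, so its effect in this assay is unknown. Among the compounds with values here, the account expects a modest weakening, possibly at the edge of the scatter, since the only other compound with an aromatic ring set directly on the ring nitrogen with a number, compound 2, gives 5740 nM but also differs at the linking atom. Compound 4 is therefore estimated at 1200 nM (range 300 nM to 5000 nM), a step of a 2.4-fold higher number from compound 3 to compound 4 (0.37 log units; beyond the scatter) expected.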

Compound 4, half-maximal inhibitory concentration: 63 nM
For compound 4 the middle estimate is 19-fold (1.28 log units) above the measured one, outside the stated range (below it).
By their numbers in this assay, from the lowest: compound 4; then compound 3; then compound 2.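

In this assay, for the compounds shown here, setting 3,4-dichlorophenyl in place of benzyl on the amide-type nitrogen in a ring gives an 8.1-fold lower number from compound 3 to compound 4 (0.91 log units; beyond the scatter), the only single change read at this position. It shows that this position responds to the group it carries, and that an aromatic ring set directly on the nitrogen can go with a lower number. Nothing measured here explains the step.

The compounds shown do not separate the loss of the benzyl arrangement from the gain of the two chlorine atoms. As far as these compounds go, how an unsubstituted phenyl, a 3,4-dichlorobenzyl group or a longer chain ending in an amine would read on this nitrogen stays open.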